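Replacing a Hydroxyethyl with an Aminopropyl Side Chain

The source may report more compounds than this note shows. Statements on the series, on what has been measured and on what is new or still open speak of the compounds shown alone.

Compound 2 `COc1ccc(F)cc1-c1cccc(-c2nn(CCO)c(=O)o2)c1` carries a 2-hydroxyethyl group on an aromatic nitrogen of the shared core. In a functional assay on the whole organism (strain Wistar albino) for inhibition, with Rattus norvegicus as the target, read by paw edema, with stated times of 30 min and 1.5 h, at a dose of 10 mg/kg by the oral route (a higher number here means more inhibition at the dose given (going by the name of the read-out), a lower number less inhibition), compound 2 gives 53%. Among the measured compounds shown here, only one other compound has been measured: compound 1 `COc1ccc(F)cc1-c1cccc(-c2n[nH]c(=O)o2)c1`, which bears hydrogen on that aromatic nitrogen and in this assay gives 49%, a number within the scatter of compound 2. For the measured compounds named here, the single measured step, a number 4 percentage points higher from compound 1 to compound 2 (within the scatter), is therefore within the scatter.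

Compound 3 `COc1ccc(F)cc1-c1cccc(-c2nn(CCCN)c(=O)o2)c1` differs from compound 2 by aminomethyl in place of hydroxy on a saturated chain carbon, two bonds along the chain from an aromatic nitrogen. Going by the values given here, no measured step bears directly on this exchange; the only step available, a number 4 percentage points higher from compound 1 to compound 2 (within the scatter), concerns the same side chain and stayed within the scatter. Compound 3 is accordingly expected to give about 50% in this assay, with a range from 35% to 65%, and the expected step of a number 3 percentage points lower from compound 2 to compound 3 (within the scatter) is not expected to exceed the scatter.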

Compound 3, a percentage reported as inhibition, in the whole organism at one dose (the size of the read-out at that dose, not a potency): 55%
Compound 3: the middle estimate sits 5 percentage points below what was measured, within the range that was stated.
By their numbers in this assay, from the lowest: compounds 1, 2 and 3 (each within the scatter of the next).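

In this assay, aminomethyl in place of hydroxy on a saturated chain carbon, two bonds along the chain from an aromatic nitrogen, gives a number 2 percentage points higher from compound 2 to compound 3 (within the scatter), so the terminal oxygen of the side chain can give way to an amine without a step that exceeds the scatter. Set against the hydrogen of compound 1, 3-aminopropyl gives a number 6 percentage points higher from compound 1 to compound 3 (within the scatter), so that neither of the two side chains on this nitrogen has yet separated from hydrogen in this read-out. Nothing at hand explains why these numbers lie so close together.

On these data alone, whether any group at this position can move the number beyond the scatter remains open, for instance a carboxylic acid, a tertiary amine or a longer chain. Readings at a single dose also leave open how the three compounds compare in potency.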